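The source may report more compounds than this note shows. Statements on the series, on what has been measured and on what is new or still open speak of the compounds shown alone.

In an ADME assay on HEK-293T cells (Homo sapiens) for cytotoxicity, read by CCK-8 assay, with a stated time of 48 h (on this read-out lower numbers stand for higher toxicity in this test and higher numbers for lower toxicity in this test), compound 1 (`O=C(CNc1nc(N2CCc3ccccc3C2)nc2ccccc12)Nc1ccc2ccccc2c1`) reads > 100000 nM as a limit of the assay, not a number. Among the compounds with values here, compound 2 (`O=C(CNc1nc(N2CCCC2)nc2ccccc12)Nc1ccc2ccccc2c1`) gives 59900 nM in this assay and so holds the only actual number so far. Within the data shown here, the one measured step is an at least 1.6-fold lower number from compound 1 to compound 2 (0.22 log units; that floor lies within the scatter) and it concerns the group on an aromatic carbon, so it bears only weakly on the next change. Among the measured compounds shown here, compound 3 (`O=C(CNc1nc(N2CCCC2)nc2ccccc12)Nc1cc(Cl)cc(Cl)c1`) has 3,5-dichlorophenyl in place of naphthalen-2-yl on an amide-type nitrogen and no step at that place has been measured. No step beyond the scatter is therefore expected in this assay, and no firm direction. The expected step is a 1.5-fold lower number from compound 2 to compound 3 (0.18 log units; within the scatter) as an estimate only. The estimate for compound 3 is 40000 nM with an expected range from 15000 nM to 100000 nM on this read-out.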

Compound 3, half-maximal cytotoxic concentration: 15900 nM
Compound 3: the middle estimate sits 2.5-fold (0.40 log units) above what was measured; the measured number falls inside the stated range.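

In this assay, the group on the amide-type nitrogen moves the read-out: 3,5-dichlorophenyl in place of naphthalen-2-yl gives a 3.8-fold lower number from compound 2 to compound 3 (0.58 log units; beyond the scatter), toward higher toxicity in this test. Within the data shown here, this modest step is the first with a measured size, as the earlier change at the aromatic carbon gave only a floor within the scatter. The change replaces two aromatic rings with one ring carrying two chlorine atoms, and the pair cannot separate the loss of a ring from the gain of chlorine.

As far as these compounds go, whether a plain phenyl or a 3-chlorophenyl gives a number nearer compound 2 or compound 3 remains open. It is also open whether the step carries over to the 1,2,3,4-tetrahydroisoquinolin-2-yl analogue, since compound 1 sits at a limit, not a number: the limit of > 100000 nM in this assay, at which 1 of the 3 values shown sits.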